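Replacing trifluoromethyl with methyl in compound 2

The source may report more compounds than this note shows. Statements on the series, on what has been measured and on what is new or still open speak of the compounds shown alone.

Measured in an ADME assay for permeability, using PAMPA (a lower number here means that the compound crosses the layer more slowly, a higher number that the compound crosses the layer faster), so far:
Compound 1 `NS(=O)(=O)c1ccc(NC(=O)c2cc(Cl)ccc2O)cc1` gives < 1 10^-6 cm/s
Compound 2 `O=C(Nc1ccc(C(F)(F)F)cc1)c1cc(Cl)ccc1O` gives < 22.3 10^-6 cm/s
Compound 3 `O=C(Nc1ccc(C(F)(F)F)cc1Cl)c1cc(Cl)ccc1O` gives "not determined" (no result reported)

Compound 2 stands at < 22.3 10^-6 cm/s and that is a limit, not a number. Compound 1 gives < 1 10^-6 cm/s and that too is a limit. The change to compound 4 `Cc1ccc(NC(=O)c2cc(Cl)ccc2O)cc1` is methyl in place of trifluoromethyl on an aromatic carbon and amounts to methyl in place of trifluoromethyl on an aromatic carbon. Among the measured compounds shown here, the only measured step bearing on it is a step that the two limits leave unreadable from compound 1 to compound 2 and its size cannot be read. No size therefore carries over to this assay here, so no step beyond the scatter is expected, in either direction. The estimated step is a step that the limit leaves unreadable from compound 2 to compound 4 and it remains only an expectation. The value expected for compound 4 is 12 10^-6 cm/s with an estimated range of 3 10^-6 cm/s to 30 10^-6 cm/s around it.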

Compound 4, apparent permeability: 21 10^-6 cm/s
Compound 4: the middle estimate sits 1.8-fold (0.24 log units) below what was measured; measured number inside the range.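

In this assay, among the compounds shown here, compound 4 gives 21 10^-6 cm/s, the first value that is a number and not a limit, so this position can hold a group that leaves a readable result. Methyl in place of sulfamoyl gives an at least 21-fold higher number from compound 1 to compound 4 (1.32 log units; beyond the scatter). Compound 2 gives < 22.3 10^-6 cm/s, which is a limit, and the step from it to compound 4 cannot be read.

Going by these compounds, whether methyl and trifluoromethyl truly differ at this position stays open. So does how this assay responds here to an amine or a carboxylic acid.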